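The compounds below may be only part of what the source reports. "The series", "measured", "known", "first", "only" and "open" are said of these compounds alone.

Two compounds in this series, compound 1 `Cc1cccc(-c2cc(-c3ccc(Cl)o3)cc(-c3ccsc3)n2)c1` and compound 2 `Clc1ccc(-c2cc(-c3ccco3)nc(-c3cccs3)c2)o1`, have been measured. In a functional assay on HeLa cells (Homo sapiens) for cytotoxicity, in the presence of a further agent that is not named here (a higher number here means a weaker inhibitor, a lower number a stronger inhibitor), compound 1 gives 20300 nM, and compound 2 gives 18800 nM. Compound 2 has the lower of the two numbers, but its gap to compound 1 lies within the scatter, so the two cannot be ranked. Compound 3 `Clc1ccc(-c2cc(-c3ccc(Cl)o3)cc(-c3cccs3)n2)cc1` differs from compound 2 by 4-chlorophenyl in place of furan-2-yl on an aromatic carbon. Within the data shown here, no step of this kind has been measured, and both numbers so far cluster closely, so compound 3 is expected to change little beyond the scatter, a step of a 1.1-fold lower number from compound 2 to compound 3 (0.04 log units; within the scatter). Compound 3 is thus estimated at 17000 nM, with a range from 6000 nM to 50000 nM.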

Compound 3, half-maximal inhibitory concentration: 21300 nM
Beside the measured number, compound 3's estimate is 1.3-fold (0.10 log units) below it; the range from low to high includes it.
By their numbers in this assay, from the lowest: compounds 2, 1 and 3 (each within the scatter of the next).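

In this assay, placing 4-chlorophenyl instead of furan-2-yl on the aromatic carbon next to the ring nitrogen gives a 1.1-fold higher number from compound 2 to compound 3 (0.05 log units; within the scatter) and so stays within the scatter. At this position, then, a six-membered aromatic ring of carbon only and a five-membered aromatic ring with one hetero atom cannot be told apart. No available evidence bears on why this is so. Going by these compounds, whether an amine or a carboxylic acid at this position would move the number beyond the scatter remains open. So does the role of the 5-chlorofuran-2-yl and thiophen-2-yl groups.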